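Fluoro to methoxy on the aryl alkyne of compound 3

A few compounds are considered here, and "the series" means these few. Any claim that something is new, unique, unknown or untested is made for them only; others in the source may bear on it.

Compound 1 `Cc1nncc(C#Cc2ccccc2)n1` and compound 2 `Cc1cnc(C#Cc2ccccc2)nn1` carry an unsubstituted phenyl on the alkyne; in a functional assay on CHO-K1 cells for antagonist activity at metabotropic glutamate receptor 5 (Homo sapiens), read by calcium flux (on this read-out higher numbers stand for weaker inhibition and lower numbers for stronger inhibition), compound 1 gives "not active" (no number reported) and compound 2 gives "not active" (no number reported), neither with a number. Among the measured compounds shown here, compound 3 `Cc1cnnc(C#Cc2cccc(F)c2)n1` adds a fluoro on that ring, and in this assay compound 3 gives 96 nM, the only number so far, so it stands alone without a measured step to compare against. Compound 4 `COc1cccc(C#Cc2nncc(C)n2)c1` differs from compound 3 by methoxy in place of fluoro on an aromatic carbon, on an aromatic carbon of a six-membered aromatic ring of carbon only. For the measured compounds named here, no step between measured compounds is available for this change; the expectation is a small shift toward weaker inhibition, a 1.7-fold higher number from compound 3 to compound 4 (0.22 log units; within the scatter), within or just beyond the scatter. Compound 4 is thus estimated at 160 nM in this assay, in a range from 50 nM to 500 nM.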

Compound 4, half-maximal inhibitory concentration: 312 nM
Estimate against measurement, compound 4: 2.0-fold (0.29 log units) below; the range from low to high includes it.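

In this assay, among the compounds shown here, methoxy in place of fluoro on this aromatic carbon gives a 3.3-fold higher number from compound 3 to compound 4 (0.51 log units; beyond the scatter), the first step that can be read as a number. The position therefore accepts methoxy with a modest loss and a measurable inhibition remains. No measurement shown here accounts for the shift.

Going by these compounds, how a chloro, a nitrile or an amine would read on this same carbon remains open. So does whether the fluoro to methoxy step keeps its size elsewhere on the ring.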